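The source may report more compounds than this note shows. Statements on the series, on what has been measured and on what is new or still open speak of the compounds shown alone.

Measured so far:
compound 1, `CSc1ccc(C)cc1NCC1=NCCN1` — 96%
compound 2, `CSc1cc(F)ccc1NCC1=NCCN1` — 78%

In a functional assay for agonist activity at Alpha-1B adrenergic receptor (Homo sapiens) (a lower number here means a smaller maximal response, a higher number a larger maximal response), compound 1 stands highest of the two numbers; compound 2 lies lower, and the gap between them is beyond the scatter. Compound 3, `CSc1ccc(Cl)cc1NCC1=NCCN1`, is not yet measured. It differs from compound 1 by chloro in place of methyl on an aromatic carbon. Among the compounds with values here, no step between measured compounds that differ in one place is available, so the size of this change is not anchored by anything measured. The expectation is a small step, downward or none beyond the scatter, of a number 8 percentage points lower from compound 1 to compound 3 (within the scatter). Compound 3 is therefore expected to reach about 88%, with a range from 72% to 100%.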

Compound 3, largest response reached (reported as maximum), in percent of the reference or control that the assay uses: 103%
Estimate against measurement, compound 3: 15 percentage points below, outside the stated range (above it).
By their numbers in this assay, from the lowest: compound 2; then compounds 1 and 3 (each within the scatter of the next).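

In this assay, chloro in place of methyl on this aromatic carbon, para to a methylsulfanyl group, gives a number 7 percentage points higher from compound 1 to compound 3 (within the scatter). Within the data shown here, this is the first step that isolates a single change, and it shows that this position accepts chloro as well as methyl without a change in maximal response beyond the scatter. Nothing available explains this equivalence.

As far as these compounds go, whether an amine or a carboxylic acid at this position would keep the response remains open. So does whether a longer chain, such as propyl, would do so.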